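The compounds below may be only part of what the source reports. "The series", "measured", "known", "first", "only" and "open" are said of these compounds alone.

Measured so far in an ADME assay on microsomes from liver (Rattus norvegicus) for metabolic stability, read by LC-MS, tested at 1 uM; a higher number here means that the compound lasts longer, a lower number that the compound disappears faster:
- compound 1 `CC(C)(C)n1nc(Oc2cc(F)cc(F)c2)c2c(N)ncnc21` gives 0.55 h as a number
- compound 2 `Nc1ncnc2c1c(Cc1cc(F)cc(F)c1)nn2CC1CCNCC1` gives > 1 h as a limit
- compound 3 `CN1CCC(Cn2nc(Oc3cccc(Cl)c3)c3c(N)ncnc32)CC1` gives > 1 h as a limit

Compound 3 has no exact half-life on these numbers. It stands at the limit of > 1 h in this assay, at which 2 of the 3 values shown sit, and is therefore a weak anchor for any comparison.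

The next compound to be measured is compound 4 `Nc1ncnc2c1c(Oc1cccc(Cl)c1)nn2CC1CCNC1`, which differs from compound 3 in one place. The change is pyrrolidin-3-yl in place of 1-methylpiperidin-4-yl on a saturated chain carbon bound to an aromatic nitrogen and reads, in words, as pyrrolidin-3-yl in place of 1-methylpiperidin-4-yl on a saturated chain carbon bound to an aromatic nitrogen. The same difference can also be read as (1-methylpiperidin-4-yl)methyl to (pyrrolidin-3-yl)methyl.

For the measured compounds named here, no pair of measured compounds differs in only one place, so the data give no direct size for a change of this kind. No shift beyond the usual scatter is therefore expected, in either direction. The expectation rests on compound 3, whose > 1 h is a limit. The estimated move is a step that the limit leaves unreadable from compound 3 to compound 4 and is expected to stay within the scatter. The estimated half-life of compound 4 is 1.2 h with an expected range from 0.5 h to 3 h and a real chance that the assay again reports only a limit.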

Compound 4, half-life: > 1 h
Compound 4 ended at the assay's limit; the forecaster's own chance of this, stated with the estimate: 60%; the middle value does not contradict the limit.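

No size can be read for the change from compound 3 to compound 4 in this assay because both compounds stand at the same limit: the limit of > 1 h in this assay, at which 3 of the 4 values shown sit.

The compounds shown leave open what the exact half-lives of compound 3 and compound 4 are, and whether pyrrolidin-3-yl in place of 1-methylpiperidin-4-yl changes the half-life at all.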